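The source may hold more compounds than are shown below. What is called first, only, known or untested is meant among the compounds shown, and "the series" means these compounds.

Compound 1, `C=CCSc1nnc(COc2ccccc2C2=NOC(c3ccc(Cl)cc3Cl)C2)n1NC(C)=O` — "not determined" (no result reported) in an ADME assay (MDM cells, Homo sapiens) for cytotoxicity, read by resazurin assay, with a stated time of 3 days; a higher number here means a weaker inhibitor, a lower number a stronger inhibitor. Compound 2, `CSc1nnc(COc2ccccc2C2=NOC(c3ccc(Cl)cc3Cl)C2)n1NC(=O)c1ccccc1` — 2.2 ug/mL in this assay. Compound 3, `C=CCSc1nnc(COc2ccccc2C2=NOC(c3ccc(Cl)cc3Cl)C2)n1NC(=O)CCl` — "not determined" (no result reported) in this assay.

Among the measured compounds shown here, compound 3 has no single number in this assay; compound 1 likewise has none, so the only value in the set belongs to compound 2. The change from compound 3 to compound 4, `CSc1nnc(COc2ccccc2C2=NOC(c3ccc(Cl)cc3Cl)C2)n1NC(=O)CCl`, is hydrogen in place of vinyl on a saturated chain carbon bound to a sulfur — allylsulfanyl to methylsulfanyl. For the measured compounds named here, no step between measured compounds is given for this change. Compound 2 carries the same methylsulfanyl group and gives 2.2 ug/mL. From that single anchor, the step in this assay is expected to be small, in no firm direction, and within the usual scatter. Compound 4 is therefore estimated at 3 ug/mL, with a range from 1 ug/mL to 10 ug/mL.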

Compound 4, half-maximal inhibitory concentration: 2.7 ug/mL
Compound 4: middle estimate off by 1.1-fold (0.05 log units), on the high side; measured number inside the range.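

In this assay, among the compounds shown here, chloromethyl in place of phenyl on a carbonyl carbon gives a 1.2-fold higher number from compound 2 to compound 4 (0.09 log units; within the scatter), the first reading at this position, and with the methylsulfanyl group held constant the two compounds do not separate. The change from allylsulfanyl to methylsulfanyl cannot be read, as compound 3 has no single number. Nothing available on these compounds bears on this result.

The compounds shown leave open whether an amine or a carboxylic acid on that carbonyl carbon would stay within the scatter. They also leave open how a longer chain on the sulfur would read.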